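The source may report more compounds than this note shows. Statements on the series, on what has been measured and on what is new or still open speak of the compounds shown alone.

In a functional assay on M21 cells (Homo sapiens) for antiproliferative activity, read by sulforhodamine B assay, with a stated time of 48 h (a higher number here means a weaker inhibitor, a lower number a stronger inhibitor), the measured compounds stand as follows
compound 1 `O=C1NCCN1c1ccc(S(=O)(=O)Nc2ccc(Cl)cc2)cc1` gives 90 nM
compound 2 `O=C1NCCN1c1ccc(S(=O)(=O)Nc2cccc(Cl)c2)cc1` gives 25 nM

Compound 2 holds the lower number of the pair. Within the data shown here, the only measured step is a 3.6-fold lower number from compound 1 to compound 2 (0.56 log units; beyond the scatter) and it lies beyond the scatter. Next comes compound 3 `COc1ccc(NS(=O)(=O)c2ccc(N3CCNC3=O)cc2)cc1` with 4-methoxyphenyl in place of 3-chlorophenyl on a sulfonamide nitrogen. The counted difference is 4-methoxyphenyl in place of 3-chlorophenyl on a sulfonamide nitrogen in this exchange. Among the measured compounds shown here, the measured step bears on this only in part, since no methoxy compound has a value yet. Of the two measured groups, 4-chlorophenyl is the closer match, so compound 3 is expected near compound 1 at 90 nM in this assay and not near compound 2. The expected move is a 3.6-fold higher number from compound 2 to compound 3 (0.56 log units; beyond the scatter) as a modest rise. For compound 3 the estimate is 90 nM with an expected range of 25 nM to 320 nM as the outer ends.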

Compound 3, half-maximal inhibitory concentration: 580 nM
Estimate against measurement, compound 3: 6.4-fold (0.81 log units) below, outside the stated range (above it).
By their numbers in this assay, from the lowest: compound 2; then compound 1; then compound 3.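

Going from 4-chlorophenyl to 4-methoxyphenyl gives a 6.4-fold higher number from compound 1 to compound 3 (0.81 log units; beyond the scatter) and so, on this sulfonamide nitrogen, the group carried by the ring counts and not only its placing. Among these compounds, the full exchange of 3-chlorophenyl for 4-methoxyphenyl gives a 23-fold higher number from compound 2 to compound 3 (1.37 log units; beyond the scatter) and is the largest step so far, which stretches the spread at this position well past what the chloro pair showed.

Still open, on these data alone, is whether a 3-methoxyphenyl group would follow the 3-chlorophenyl group or the 4-methoxyphenyl group, and whether a fluoro, methyl or amino group on the same ring would sit nearer chloro or methoxy. No measurement at hand bears on why methoxy ranks behind chloro in this series.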